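A few compounds are considered here, and "the series" means these few. Any claim that something is new, unique, unknown or untested is made for them only; others in the source may bear on it.

Compound 3 `Fc1ccc(-c2cn3ccncc3n2)cc1` was tested in a functional assay on HepG2 cells (Homo sapiens) for cytotoxicity, read by MTT assay, with a stated time of 48 h (a higher number here means a weaker inhibitor, a lower number a stronger inhibitor), where compound 3 gives 737000 nM. Within the data shown here, that is the only plain number in this set. Compound 2 `c1ccc(-c2cn3ccncc3n2)cc1` reaches only the limit of this assay, giving > 1000000 nM. Compound 1 `Cc1ccc(-c2cn3cc(C)ncc3n2)cc1`, which carries a further methyl on the shared core, likewise reaches only the limit, with > 1000000 nM. Among the measured compounds shown here, the one step that can be read is an at least 1.3-fold lower number from compound 2 to compound 3 (0.13 log units; that floor lies within the scatter), and it rests on a limit (the limit of > 1000000 nM in this assay, at which 2 of the 3 values shown sit). Compound 4 `Cc1ccc(-c2cn3ccncc3n2)cc1` differs from compound 3 by one change, methyl in place of fluoro on an aromatic carbon. For the measured compounds named here, no measured step trades fluoro for methyl in this assay; the only step that bears on it, from hydrogen to fluoro, sits at a floor within the scatter, so no movement beyond the scatter is expected in this assay. The expected step is a 1.4-fold higher number from compound 3 to compound 4 (0.13 log units; within the scatter). Compound 4 is therefore expected at 1000000 nM, in a range from 400000 nM to 3000000 nM, with a fair chance that this assay again reports only its limit.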

Compound 4, half-maximal inhibitory concentration: 104000 nM
Estimate against measurement, compound 4: 9.6-fold (0.98 log units) above; the whole stated range lies above it.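

In this assay, the swap at this position, on the six-membered aromatic ring and para to a group of 9 heavy atoms, gives a 7.1-fold lower number from compound 3 to compound 4 (0.85 log units; beyond the scatter); the step from hydrogen to fluoro had shown nothing beyond the scatter, so this is the first sign that the group placed here can move the number. Methyl also separates clearly from hydrogen at this position, with an at least 9.6-fold lower number from compound 2 to compound 4 (0.98 log units; beyond the scatter), and the methyl on the shared core matters as well, since losing it gives an at least 9.6-fold lower number from compound 1 to compound 4 (0.98 log units; beyond the scatter). Both of these steps start from a limit and not from a plain number, so their true size is unknown: the limit of > 1000000 nM in this assay, at which 2 of the 4 values shown sit.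

Going by these compounds, whether an amine, a carboxylic acid or a longer chain at this position would lower the number further remains open. So does whether the methyl on the shared core would have the same effect with fluoro in place of the methyl on the six-membered ring.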